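The compounds below may be only part of what the source reports. "The series", "measured", "known", "first", "only" and "open" are said of these compounds alone.

Measured compounds:
compound 1, `CC(=O)N1N=C(c2ccc(N3CCN(C)CC3)cc2)CC1c1ccc(N(C)C)cc1`, -0.8%
compound 2, `CC(=O)N1N=C(c2ccc(-n3ccnc3)cc2)CC1c1ccc(N(C)C)cc1`, -9.7%

In a functional assay on HCC1806 cells (Homo sapiens) for inhibition, read by sulforhodamine B assay, tested at 10 uM (a lower number here means less inhibition, a higher number more inhibition at the concentration tested (going by the name of the read-out)), compound 1 gives -0.8% and compound 2 gives -9.7%; the two numbers lie within the scatter of each other, so compound 2 cannot be set apart from compound 1 on these data. For the measured compounds named here, the one measured step, a number 8.9 percentage points lower from compound 1 to compound 2 (within the scatter), concerns the group on an aromatic carbon and is within the scatter.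

Compound 3, `CN(C)c1ccc(C2CC(c3ccc(-n4ccnc4)cc3)=NN2S(C)(=O)=O)cc1`, differs from compound 2 at another place: methylsulfonyl in place of acetyl on an amine nitrogen in a ring. Going by the values given here, no measured step touches the group on that ring nitrogen, so the single step available offers no direct guide. What the two measured compounds do show is that neither reaches a reading beyond the scatter around zero in this assay. Compound 3 is therefore expected to behave much like compound 2, with an expected step of a number 6.7 percentage points higher from compound 2 to compound 3 (within the scatter). The estimate for compound 3 is -3%, with a range from -20% to 15%.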

Compound 3, a percentage reported as inhibition, at one concentration (the size of the read-out at that concentration, not a potency): 11.3%
Compound 3: the middle estimate sits 14.3 percentage points below what was measured; the range from low to high includes it.
By their numbers in this assay, from the lowest: compounds 2 and 1 (each within the scatter of the next); then compound 3.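

In this assay, for the compounds shown here, the group on the amine nitrogen in a ring proved able to shift the reading: methylsulfonyl in place of acetyl gave a number 21 percentage points higher from compound 2 to compound 3 (beyond the scatter), the first step in this small set to lie beyond the scatter. Going by these compounds alone, this sets the position apart from the group on the aromatic carbon, where the only measured change gave a number 8.9 percentage points lower from compound 1 to compound 2 (within the scatter), although one step at each place is thin ground for any pattern. Nothing measured here speaks to why the exchange of acetyl for methylsulfonyl raises the reading.

The compounds shown leave open whether ethylsulfonyl or phenylsulfonyl on that ring nitrogen would carry the reading further, and whether a urea there would read like acetyl or like methylsulfonyl. They also leave open whether methylsulfonyl gives a similar step when 4-methylpiperazin-1-yl stands on the aromatic carbon.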